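The source may report more compounds than this note shows. Statements on the series, on what has been measured and on what is new or still open speak of the compounds shown alone.

Measured compounds:
compound 1, `N#CNC(=N)NCCCCCn1nc(-c2ccccc2)ccc1=O` — > 100 mg/kg
compound 2, `CCC/N=C(/NC#N)NCCCCCn1nc(-c2ccccc2)ccc1=O` — > 100 mg/kg

Compound 1 has no number in a functional assay on the whole organism (stomach) with Rattus norvegicus as the target; on this read-out higher numbers stand for an effect only at larger amounts of compound and lower numbers for an effect already at smaller amounts: it reaches only the limit of the measurement, > 100 mg/kg. Compound 2 likewise reaches only the limit in this assay, > 100 mg/kg. Among the measured compounds shown here, the one measured step, a step that the two limits leave unreadable from compound 1 to compound 2, is therefore unreadable, as both ends sit at a limit; it exchanges a group of 8 heavy atoms for a group of 5 heavy atoms on an amine nitrogen and says nothing about size or direction.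

Compound 3, `CC/N=C(\S)NCCCn1nc(-c2ccccc2)ccc1=O`, is not yet measured in this assay. It differs from compound 1 by a group of 6 heavy atoms (3 carbon, 2 nitrogen, 1 sulfur; no ring) in place of a group of 8 heavy atoms (4 carbon, 4 nitrogen; no ring), on a saturated chain carbon, three bonds along the chain from an aromatic nitrogen. For the measured compounds named here, no measured step touches this change, and the only thing known of the series is the limit of > 100 mg/kg in this assay, at which 2 of the 2 values shown sit, so there is no basis for expecting a readable effect. Compound 3 is estimated at 150 mg/kg, spanning 30 mg/kg to 1000 mg/kg, most likely again reported as a limit. The expected step that the limit leaves unreadable from compound 1 to compound 3 is thus no change beyond the scatter.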

Compound 3, dose for half-maximal effect: > 100 mg/kg
Compound 3: a limit, no number; the forecaster's own chance of this, stated with the estimate: 70%; the middle value is on the limit's open side.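

In this assay compound 3 gives > 100 mg/kg, which is a limit and not a number. Compound 1 also stands only at a limit, so the step between compound 1 and compound 3 cannot be read. The compounds shown leave open whether any change to this series yields a numerical value in this assay.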